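A few compounds are considered here, and "the series" means these few. Any claim that something is new, unique, unknown or untested is made for them only; others in the source may bear on it.

In a functional assay on A2780 cells (Homo sapiens) for inhibition (on this read-out higher numbers stand for weaker inhibition and lower numbers for stronger inhibition), compound 1 `CCNC(=O)c1noc(-c2cc(C(C)C)c(O)cc2O)c1-c1cc(C(=O)NC)no1` gives 100 nM. Compound 2 `CCNC(=O)c1cc(-c2c(C(=O)NCC)noc2-c2cc(C(C)C)c(O)cc2O)on1` carries the change (methyl in place of hydrogen on a saturated chain carbon bound to an amide-type nitrogen), and in this assay compound 2 gives 43 nM, a step of a 2.3-fold lower number from compound 1 to compound 2 (0.37 log units; beyond the scatter). Compound 3 `CCNC(=O)c1noc(-c2cc(C(C)C)c(O)cc2O)c1-c1ccn(CC)n1` differs from compound 1 by 1-ethyl-1H-pyrazol-3-yl in place of 3-(methylcarbamoyl)-1,2-oxazol-5-yl on an aromatic carbon, and in this assay compound 3 gives 13 nM. Compound 4 `CCCn1ccc(-c2c(C(=O)NCC)noc2-c2cc(C(C)C)c(O)cc2O)n1` has not yet been measured; it differs from compound 3 by methyl in place of hydrogen on a saturated chain carbon, two bonds along the chain from an aromatic nitrogen. This is the same kind of change as that from compound 1 to compound 2, but not the same: there the methyl entered on a saturated chain carbon bound to an amide-type nitrogen, here on a saturated chain carbon two bonds along the chain from an aromatic nitrogen, and the cores differ as noted. The step from compound 3 to compound 4 is expected to be a 1.3-fold lower number from compound 3 to compound 4 (0.11 log units; within the scatter), resting on a 2.3-fold lower number from compound 1 to compound 2 (0.37 log units; beyond the scatter) with caution for the different place. In this assay compound 4 is expected to give 10 nM, estimated between 4 nM and 25 nM.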

Compound 4, half-maximal inhibitory concentration: 27 nM
Beside the measured number, compound 4's estimate is 2.7-fold (0.43 log units) below it, and the stated range ends below it.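

In this assay, going from 1-ethyl-1H-pyrazol-3-yl to 1-propyl-1H-pyrazol-3-yl gives a 2.1-fold higher number from compound 3 to compound 4 (0.32 log units; beyond the scatter), so the added methyl does not carry over from one core to the other: the same change on two cores in this assay, a 2.3-fold lower number (0.37 log units; beyond the scatter) from compound 1 to compound 2 and a 2.1-fold higher number (0.32 log units; beyond the scatter) from compound 3 to compound 4, 4.8-fold (0.68 log units) apart, beyond the scatter of two such steps

Putting 1-propyl-1H-pyrazol-3-yl in place of 3-(ethylcarbamoyl)-1,2-oxazol-5-yl gives a 1.6-fold lower number from compound 2 to compound 4 (0.20 log units; within the scatter), which lies within the scatter, while putting it in place of 3-(methylcarbamoyl)-1,2-oxazol-5-yl gives a 3.7-fold lower number from compound 1 to compound 4 (0.57 log units; beyond the scatter). With one pair on each core, and the methyl in a different place in each pair, this does not show whether the place or the core decides the outcome, nor why.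

From the compounds shown here alone, whether a butyl group, or a chain ending in an amine, in place of the propyl of compound 4 would give a higher or lower number remains open.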